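Urea Aryl Swap on a Dimethoxy Quinazoline Series

The source may report more compounds than this note shows. Statements on the series, on what has been measured and on what is new or still open speak of the compounds shown alone.

Compound 1 `COc1ccc(NC(=O)Nc2cccc(CNc3ncnc4ccccc34)c2)cc1` gives 27300 nM in a functional assay on MGC-803 cells (Homo sapiens) for antiproliferative activity, read by MTT assay; a higher number here means a weaker inhibitor, a lower number a stronger inhibitor.
Compound 2 `O=C(Nc1cccc(CNc2ncnc3ccccc23)c1)Nc1cccc(C(F)(F)F)c1` reaches only the limit > 50000 nM in this assay.
Compound 3 `COc1cc2ncnc(NCc3cccc(NC(=O)Nc4ccccc4C)c3)c2cc1OC` likewise gives only the limit > 50000 nM in this assay.

Compound 3 therefore stands at the upper edge of the measured values, with no number of its own. Compound 4 `COc1cc2ncnc(NCc3cccc(NC(=O)Nc4ccc(F)cc4)c3)c2cc1OC` differs from it by 4-fluorophenyl in place of 2-methylphenyl on an amide-type nitrogen. Among the measured compounds shown here, the only measured step, an at least 1.8-fold higher number from compound 1 to compound 2 (0.26 log units; that floor lies within the scatter), changes the same amide-type nitrogen but on another core and with other groups, and it moved toward the limit (the limit of > 50000 nM in this assay, at which 2 of the 3 values shown sit). For the measured compounds named here, no step concerns the present pair directly, and compound 1 alone shows that a substituted phenyl on this nitrogen can give a number below the limit. The expected step of an at least 1.1-fold lower number from compound 3 to compound 4 (0.04 log units; that floor lies within the scatter) is none beyond the scatter; compound 4 is estimated at 45000 nM, between 15000 nM and 150000 nM, with a real chance of another limit.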

Compound 4, half-maximal inhibitory concentration: 42100 nM
Estimate against measurement, compound 4: 1.1-fold (0.03 log units) above; low and high end bracket the measured number.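

Compound 3 gives > 50000 nM in this assay, which is a limit and not a number. As far as these compounds go, the change to 4-fluorophenyl on the amide-type nitrogen therefore reads only as a floor, an at least 1.1-fold lower number from compound 3 to compound 4 (0.07 log units; that floor lies within the scatter), and its true size stays unknown. It does show that a substituted phenyl at this nitrogen can give a measured number on the shared core of compound 3 and compound 4, not only the limit: the limit of > 50000 nM in this assay, at which 2 of the 4 values shown sit.

The compounds shown leave open whether the fluorine or the absence of the methyl counts here. They also leave open what an amine or a carboxylic acid on this phenyl would give.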